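Extending the Aryl Arm of Compound 2 by One Carbon

The source may hold more compounds than are shown below. What is called first, only, known or untested is meant among the compounds shown, and "the series" means these compounds.

For the measured compounds named here, compound 2 `CN1CCC[C@@H]1Cn1nc(Cc2ccc(F)c(F)c2)c2ccccc2c1=O` gives 316 nM in an assay for binding affinity to Alpha-1B adrenergic receptor (Homo sapiens) (a lower number here means a stronger inhibitor, a higher number a weaker inhibitor), and holds the only number among the two values shown. Compound 1 `CN1CCC[C@@H]1Cn1nc(CC2CCCCC2)c2ccccc2c1=O` stops at a limit in this assay, > 1990 nM (the limit of > 1990 nM in this assay, at which 1 of the 2 values shown sits). Going by the values given here, the single measured step, an at least 6.2-fold lower number from compound 1 to compound 2 (0.79 log units; beyond the scatter), shows an aromatic ring on this carbon giving a lower number than a saturated one. Compound 3 `CN1CCC[C@@H]1Cn1nc(CCc2ccccc2)c2ccccc2c1=O` is not yet measured. It differs from compound 2 by benzyl in place of 3,4-difluorophenyl on a saturated chain carbon bound to an aromatic carbon; cut one bond further out, the same difference reads 3,4-difluorobenzyl to phenethyl. Among the compounds with values here, the ring stays aromatic, so the measured step does not suggest a return toward the limit seen for compound 1, but no measured pair shows the loss of the two fluorines or the longer chain. Compound 3 is therefore expected to weaken only slightly, a 1.9-fold higher number from compound 2 to compound 3 (0.28 log units; within the scatter), and is estimated at 600 nM (range 200 nM to 2000 nM).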

Compound 3, inhibition constant: 200 nM
Compound 3: the middle estimate sits 3.0-fold (0.48 log units) above what was measured; the measured number falls inside the stated range.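

In this assay, replacing the 3,4-difluorobenzyl arm with phenethyl gives a 1.6-fold lower number from compound 2 to compound 3 (0.20 log units; within the scatter), so on this saturated chain carbon, removing the two fluorines and adding one carbon together leave no change that can be told from the scatter. An aromatic ring without fluorine also stands clear of the saturated ring, with an at least 9.9-fold lower number from compound 1 to compound 3 (0.99 log units; beyond the scatter), which shows that fluorine is not required for the aromatic arm to outperform cyclohexyl in this pair. Compound 1 stands at a limit and not at a number, so the full size of that step stays unknown: the limit of > 1990 nM in this assay, at which 1 of the 3 values shown sits.

Loss of the fluorines and lengthening of the chain occur together in this one step, and the compounds shown do not separate them, so either change could matter alone. Also open, from the compounds shown here alone, is how a longer chain, such as 3-phenylpropyl, or an amine on the aromatic ring would read in this assay.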